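Two scaffold-sharing binders and a heteroaryl swap

The compounds below may be only part of what the source reports. "The series", "measured", "known", "first", "only" and "open" are said of these compounds alone.

Measured so far in an assay on isolated protein for binding affinity to somatostatin receptor type 1 (Homo sapiens); on this read-out higher numbers stand for weaker binding and lower numbers for tighter binding:
- compound 1 `COC(=O)c1cc(C[C@H](C)CN2C[C@@H]3CCCC[C@@H]3[C@H](C(=O)N3CCN(c4ccc([N+](=O)[O-])cc4)CC3)C2)cc(C(=O)OC)c1`: 933 nM
- compound 2 `Cc1nc2cc(C[C@H](C)CN3C[C@@H]4CCCC[C@@H]4[C@H](C(=O)N4CCN(c5ccc(F)c(F)c5)CC4)C3)ccc2o1`: 1380 nM

Going by the values given here, compound 1 and compound 2 share the same core and differ at two places, so no single-change step can be drawn between them; their two values in this assay lie within the usual scatter of each other, and nothing more than that can be read from the pair.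

Compound 3 `C[C@@H](Cc1ccc2ncnn2c1)CN1C[C@@H]2CCCC[C@@H]2[C@H](C(=O)N2CCN(c3ccc(F)c(F)c3)CC2)C1` is the unmeasured one. It departs from compound 2 at one place only: a group of 9 heavy atoms (6 carbon, 3 nitrogen; one five-membered aromatic ring with 3 hetero atoms, one six-membered aromatic ring with 1 hetero atom) in place of a group of 10 heavy atoms (8 carbon, 1 nitrogen, 1 oxygen; one five-membered aromatic ring with 2 hetero atoms, one six-membered aromatic ring of carbon only), on a saturated chain carbon, three bonds along the chain from an amine nitrogen in a ring. Both the departing and the arriving group are fused two-ring aromatics with no hydrogen-bond donors, and the count of hydrogen-bond acceptors rises by one, as given above.

Among the compounds with values here, no measured pair in this set changes this position alone, so there is no step to lean on. The expectation is therefore that compound 3 stays close to compound 2, with no change beyond the scatter. The expected step is a 1.1-fold higher number from compound 2 to compound 3 (0.04 log units; within the scatter). Compound 3 is estimated at 1500 nM, with a likely range from 500 nM to 4500 nM.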

Compound 3, dissociation constant: 9120 nM
Compound 3: the middle estimate sits 6.1-fold (0.78 log units) below what was measured, and the stated range ends below it.
By their numbers in this assay, from the lowest: compounds 1 and 2 (each within the scatter of the next); then compound 3.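

In this assay the exchange of the 2-methyl-1,3-benzoxazol-5-yl group for the fused two-ring aromatic of 6 carbon and 3 nitrogen atoms brings a 6.6-fold higher number from compound 2 to compound 3 (0.82 log units; beyond the scatter) and gives this position its first single-change step. The earlier compounds shown here differed at two places, so they could say nothing about this saturated chain carbon, three bonds along the chain from an amine nitrogen in a ring. This pair shows that the position is not indifferent to what it carries, even though both groups are fused two-ring aromatics with no hydrogen-bond donors and no net charge. Nothing measured here accounts for the size of this step.

The two groups differ in several ways at once, including the ring oxygen, the methyl group and the number of ring nitrogens, so a single exchange cannot show which of these differences matters. As far as these compounds go, it also remains open whether a single-ring group such as phenyl or pyridine, or a benzoxazole without the methyl group, would read closer to compound 2 or to compound 3.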